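Trifluoromethylphenyl ketone replacing the naphthyl ketone

This account rests on a few compounds, and the source may have more. Where it says the series, first, only, none or still open, it means among the compounds named here.

Measured compounds: compound 1 `COc1cc(-c2nnc3n2NC(c2ccco2)C(C(=O)c2ccc(Cl)cc2)S3)cc(OC)c1OC`, 67800 nM; compound 2 `COc1cc(-c2nnc3n2NC(c2ccco2)C(C(=O)c2ccc(C)cc2)S3)cc(OC)c1OC`, 7500 nM; compound 3 `COc1cc(-c2nnc3n2NC(c2ccco2)C(C(=O)c2cccc4ccccc24)S3)cc(OC)c1OC`, > 100000 nM.

In a functional assay on PC-3 cells (Homo sapiens) for cytotoxicity, read by MTT assay, with a stated time of 48 h (a higher number here means a weaker inhibitor, a lower number a stronger inhibitor), compound 3 gives only a limit of the assay, > 100000 nM. Compound 1 sits at 67800 nM and compound 2 at 7500 nM; the step of a 9.0-fold lower number from compound 1 to compound 2 (0.96 log units; beyond the scatter) is beyond the scatter, and an at least 13-fold higher number from compound 2 to compound 3 (1.12 log units; beyond the scatter) is large, while an at least 1.4-fold higher number from compound 1 to compound 3 (0.16 log units; that floor lies within the scatter) lies within the scatter. Compound 4 `COc1cc(-c2nnc3n2NC(c2ccco2)C(C(=O)c2ccc(C(F)(F)F)cc2)S3)cc(OC)c1OC` differs from compound 3 by 4-(trifluoromethyl)phenyl in place of naphthalen-1-yl on a carbonyl carbon, bringing back a single para-substituted ring like those of compound 1 and compound 2. Compound 4 is therefore expected to give a number again, somewhere between compound 1 and compound 2, in this assay: an estimate of 40000 nM, from 8000 nM to 150000 nM, meaning an expected step of an at least 2.5-fold lower number from compound 3 to compound 4 (0.39 log units; beyond the scatter).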

Compound 4, half-maximal inhibitory concentration: 77500 nM
Compound 4: the middle estimate sits 1.9-fold (0.29 log units) below what was measured; measured number inside the range.
By their numbers in this assay, from the lowest: compound 2; then compounds 1 and 4 (each within the scatter of the next). At a limit, above all of these: compound 3.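

In this assay, trifluoromethyl in place of chloro gives a 1.1-fold higher number from compound 1 to compound 4 (0.06 log units; within the scatter), so the two compounds cannot be told apart. Trifluoromethyl in place of methyl gives a 10-fold higher number from compound 2 to compound 4 (1.01 log units; beyond the scatter), so among these three groups on the phenyl ring, only methyl stands apart. The step of an at least 1.2-fold lower number from compound 3 to compound 4 (0.11 log units; that floor lies within the scatter) gives only a floor, and the change from naphthalen-1-yl cannot be sized, since compound 3 stands at a limit of the assay: the limit of > 100000 nM in this assay, at which 1 of the 4 values shown sits.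

Going by these compounds, whether the lower number of compound 2 is particular to methyl remains open. An ethyl group, a methoxy group or an amine on the same ring could test this.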